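The source may hold more compounds than are shown below. What is called first, only, known or untested is meant among the compounds shown, and "the series" means these compounds.

Three compounds of the series have numbers in a functional assay on MDA-MB-231 cells (Homo sapiens) for cytotoxicity, read by MTT assay, with a stated time of 72 h; on this read-out higher numbers stand for weaker inhibition and lower numbers for stronger inhibition. Compound 1 `Cc1ccc(-c2ccc([N+](=O)[O-])cc2)n1-c1ccc(-c2nc3ccccc3s2)cc1` gives 12100 nM; compound 2 `Cc1ccc(-c2ccc([N+](=O)[O-])cc2)n1-c1ccc(-c2nc3ccc(F)cc3s2)cc1` gives 17000 nM; compound 3 `COc1ccc2nc(-c3ccc(-n4c(C)ccc4-c4ccc(F)cc4)cc3)sc2c1` gives 13800 nM. On these numbers compound 3 sits within the scatter of both others. Among the compounds with values here, the only single-site step measured, a 1.4-fold higher number from compound 1 to compound 2 (0.15 log units; within the scatter), does not bear on the change to compound 4 `COc1ccc2nc(-c3ccc(-n4c(C)ccc4-c4ccc([N+](=O)[O-])cc4)cc3)sc2c1`, which is nitro in place of fluoro on an aromatic carbon. Compound 1 and compound 3 differ in two places, and their values in this assay lie within the scatter of each other, so the pair gives no sign of a difference tied to the nitro group. No step beyond the scatter is therefore expected from compound 3 to compound 4, a 1.1-fold lower number from compound 3 to compound 4 (0.03 log units; within the scatter). The estimate for compound 4 in this assay is 13000 nM, between 6000 nM and 28000 nM.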

Compound 4, half-maximal inhibitory concentration: 12700 nM
Estimate against measurement, compound 4: 1.0-fold (0.01 log units) above; measured number inside the range.
By their numbers in this assay, from the lowest: compounds 1, 4, 3 and 2 (each within the scatter of the next).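

On this assay the change from 4-fluorophenyl to 4-nitrophenyl, para to a large group, gives a 1.1-fold lower number from compound 3 to compound 4 (0.04 log units; within the scatter) and so does not separate nitro from fluoro at this position. With nitro held in place, the methoxy steps also stay within the scatter: a 1.0-fold higher number from compound 1 to compound 4 (0.02 log units; within the scatter) for methoxy in place of hydrogen and a 1.3-fold lower number from compound 2 to compound 4 (0.13 log units; within the scatter) for methoxy in place of fluoro. No supporting data are at hand to explain this flat picture.

As far as these compounds go, whether an amine or a carboxylic acid at this position would give a step beyond the scatter remains open. So does whether the same flat picture holds in other cell lines.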